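Aryl in place of alkyl at the imidazole side chain

A few compounds are considered here, and "the series" means these few. Any claim that something is new, unique, unknown or untested is made for them only; others in the source may bear on it.

Measured compounds in an in vitro functional assay on cells for agonist activity at Bombesin receptor subtype-3 (Mus musculus), read by luminescence and calcium flux; a higher number here means that more compound is needed for the effect, a lower number that less compound is needed:
compound 1, `O=C(O)c1ccccc1-c1ccc(CCc2ncc(CC3CCCCCC3)[nH]2)cc1`, gives 5.7 nM
compound 2, `N#Cc1ccccc1Cc1cnc(CCc2ccc(-c3ccccc3C(=O)O)cc2)[nH]1`, gives 642 nM
compound 3, `CC(C)(C)Cc1cnc(CCc2ccc(-c3ccccc3C(=O)O)cc2)[nH]1`, gives 6.3 nM

Compound 3 stands second highest of the three numbers; its nearest neighbour is compound 1, within the scatter, and its furthest is compound 2, far beyond it. The shared core of all three is kept; they differ only in the group on the saturated chain carbon bound to an aromatic carbon of the imidazole.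

Compound 4, `COc1ccc(Cc2cnc(CCc3ccc(-c4ccccc4C(=O)O)cc3)[nH]2)cc1`, carries the change (4-methoxyphenyl in place of tert-butyl on a saturated chain carbon bound to an aromatic carbon).

Among the compounds with values here, two measured steps bear on this. a 110-fold higher number from compound 1 to compound 2 (2.05 log units; beyond the scatter) shows that putting an aromatic ring in place of a saturated group at this position cost a great deal, and a 100-fold lower number from compound 2 to compound 3 (2.01 log units; beyond the scatter) shows the reverse gain when the aromatic ring is taken out again. By contrast a 1.1-fold higher number from compound 1 to compound 3 (0.04 log units; within the scatter) shows that two saturated groups here are interchangeable. The entering 4-methoxyphenyl is not the 2-cyanophenyl of compound 2, so the size cannot be carried over exactly, but a large upward step is expected in this assay, reading a 24-fold higher number from compound 3 to compound 4 (1.38 log units; beyond the scatter).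

Compound 4 is therefore estimated at 150 nM, between 30 nM and 800 nM.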

Compound 4, half-maximal effective concentration: 513 nM
Beside the measured number, compound 4's estimate is 3.4-fold (0.53 log units) below it, and the stated range covers the measured number.
By their numbers in this assay, from the lowest: compounds 1 and 3 (each within the scatter of the next); then compounds 4 and 2 (each within the scatter of the next).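

In this assay, a second aromatic ring with a different substituent behaves like the first: an 81-fold higher number from compound 3 to compound 4 (1.91 log units; beyond the scatter) and a 90-fold higher number from compound 1 to compound 4 (1.95 log units; beyond the scatter) show that the large rise at this saturated chain carbon bound to an aromatic carbon is not peculiar to the 2-cyanophenyl group. The remaining step, a 1.3-fold lower number from compound 2 to compound 4 (0.10 log units; within the scatter), places the 4-methoxyphenyl and 2-cyanophenyl compounds level, so across these four compounds the two saturated groups give low numbers, the two aromatic groups give high numbers, and none of the four goes against that split. Nothing available explains why the two kinds of group part so sharply at this position.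

The compounds shown leave open whether a plain phenyl without any substituent, or a cyclohexyl ring carrying a methoxy group, would fall with the aromatic pair or with the saturated pair. They also leave open whether a longer chain carrying the 4-methoxyphenyl group would return the number to the level of compound 1 and compound 3.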